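This account rests on a few compounds, and the source may have more. Where it says the series, first, only, none or still open, it means among the compounds named here.

Series notes. Compound 1 `C/C(=C\c1cc(-c2ccc(C)nc2)co1)C(N)=O` in a functional assay on A549 cells (Homo sapiens) for cytotoxicity, read by CCK-8 assay, with a stated time of 24 h (a higher number here means a weaker inhibitor, a lower number a stronger inhibitor), gives > 50000 nM, a limit of the assay rather than a number. Compound 2 `C/C(=C\c1cc(-c2ccc(F)nc2)co1)C(N)=O` gives > 50000 nM in this assay, also a limit. The change between them is fluoro in place of methyl on an aromatic carbon. The step that the two limits leave unreadable from compound 1 to compound 2 cannot be sized because both values sit at the limit of > 50000 nM in this assay, at which 3 of the 3 values shown sit. Compound 3 `C/C(=C\c1ccc(-c2ccc(C)cc2)o1)C(N)=O` in this assay gives > 50000 nM, again a limit. The difference between the core of compound 1 and the core of compound 3 is not broken down here. Compound 4 `C/C(=C\c1ccc(-c2ccc(F)cc2)o1)C(N)=O` is not yet measured in this assay. Its change from compound 3 is fluoro in place of methyl on an aromatic carbon, the same kind of change as before, but now on a six-membered aromatic ring of carbon only rather than on a ring with 1 nitrogen, next to the ring nitrogen. The expected step is a step that the limit leaves unreadable from compound 3 to compound 4, since compound 3 stands at the limit of > 50000 nM in this assay, at which 3 of the 3 values shown sit, and the measured step that the two limits leave unreadable from compound 1 to compound 2 is unreadable. For compound 4 in this assay the estimate is 100000 nM.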

Compound 4, half-maximal inhibitory concentration: 1650 nM
For compound 4 the middle estimate is 61-fold (1.78 log units) above the measured one; measured number outside the range, below it.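

In this assay, fluoro in place of methyl on an aromatic carbon of a six-membered aromatic ring of carbon only gives an at least 30-fold lower number from compound 3 to compound 4 (1.48 log units; beyond the scatter). On these data alone, the same change on the core of compound 1 cannot be read, so these compounds neither show that the drop carries over from the core of compound 3 to the core of compound 1 nor show that it fails to, because both ends of that step stand at a limit: the limit of > 50000 nM in this assay, at which 3 of the 4 values shown sit. The result thus rests on one readable pair, and its full size stays open, with compound 3 itself at a limit.

As far as these compounds go, whether chloro or an amine at the same place would match fluoro remains open. So does the effect of a carboxylic acid in place of the amide.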